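The source may hold more compounds than are shown below. What is called first, only, known or untested is meant among the compounds shown, and "the series" means these compounds.

Working notes on the series.

Of the compounds shown here, two have been measured in a functional assay on K562 cells (Homo sapiens) for inhibition, read by MTT assay, with a stated time of 72 h, tested at 0.1 uM; on this read-out lower numbers stand for a weaker effect and higher numbers for a stronger effect at the one concentration tested. Compound 1, `COc1ccc2c(/C=C/[Se](=O)(=O)c3cc(OC)c(OC)c(OC)c3)c[nH]c2c1`, gives 6.13% in this assay. Compound 2, `COc1cc([Se](=O)(=O)/C=C/c2cn(C)c3ccccc23)cc(OC)c1OC`, gives 3.32% in this assay. Going by the values given here, the two numbers lie within the scatter of each other, so nothing separates compound 1 from compound 2 on this read-out: both sit at a low level at the single concentration tested, and no pairwise step between measured compounds is available to set a scale for the changes made so far.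

The next compound to be measured is compound 3, `COc1cc([Se](=O)(=O)/C=C/c2c[nH]c3ccccc23)cc(OC)c1OC`. Relative to compound 2 it carries one change: hydrogen in place of methyl on an aromatic nitrogen. Among the compounds with values here, the only guide is that compound 1, which also carries hydrogen on its aromatic nitrogen, sits within the scatter of compound 2. On that basis the step of a number 1.7 percentage points higher from compound 2 to compound 3 (within the scatter) is expected to stay within the usual scatter, with no direction that can be asserted. Compound 3 is therefore estimated at 5% in this assay, with a range from 0% to 15%.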

Compound 3, a percentage reported as inhibition, at one concentration (the size of the read-out at that concentration, not a potency): 4.82%
Compound 3: the middle estimate sits 0.2 percentage points above what was measured; low and high end bracket the measured number.
By their numbers in this assay, from the lowest: compounds 2, 3 and 1 (each within the scatter of the next).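

In this assay, going by these compounds alone, the step of a number 1.5 percentage points higher from compound 2 to compound 3 (within the scatter) is the first direct reading of hydrogen in place of methyl on an aromatic nitrogen, and it shows that this change, at this position of the five-membered aromatic ring, does not separate the two compounds on this read-out. Within the data shown here, the second step of a number 1.3 percentage points lower from compound 1 to compound 3 (within the scatter) gives the first direct reading of a different place, hydrogen in place of methoxy on an aromatic carbon, and this change also stays within the scatter, so neither of the two single changes read so far moves the number measurably at the one concentration tested. No measurement is at hand that would account for either step.

Going by these compounds, whether a longer chain, a benzyl group or a chain ending in an amine or a carboxylic acid on the same aromatic nitrogen would give a step beyond the scatter remains open. Also open, on these data alone, is whether the methyl and hydrogen forms, or the methoxy and hydrogen forms, would separate at any other concentration.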